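Series notes: naphthyl variation on the triazole of compound 1

The source may report more compounds than this note shows. Statements on the series, on what has been measured and on what is new or still open speak of the compounds shown alone.

Compound 1 `O=C1C=CC2(C=C1)OCC(=O)N2c1nc(-c2ccc3ccccc3c2Br)nn1-c1ccccc1` gives 50 nM in a functional assay on MDA-MB-231 cells (Homo sapiens) for antiproliferative activity, with a stated time of 5 days; a higher number here means a weaker inhibitor, a lower number a stronger inhibitor. Compound 2 `CC1OC2(C=CC(=O)C=C2)N(c2nc(-c3ccc4ccccc4c3)nn2-c2ccc3ccccc3c2)C1=O` gives 60 nM in this assay, a number within the scatter of compound 1; the two are not distinguishable on these data, and compound 1 sets one end of the pair. Compound 3 `O=C1C=CC2(C=C1)OCC(=O)N2c1nc(-c2ccc(F)c3ccccc23)nn1-c1ccccc1` differs from compound 1 as follows: 4-fluoronaphthalen-1-yl in place of 1-bromonaphthalen-2-yl on an aromatic carbon. Within the data shown here, no measured pair isolates this change, so the step from compound 1 to compound 3 is expected to be small, at most modestly weakening. Compound 3 is estimated at 80 nM, within 25 nM to 250 nM, an expected step of a 1.6-fold higher number from compound 1 to compound 3 (0.20 log units; within the scatter).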

Compound 3, half-maximal inhibitory concentration: 80 nM
Beside the measured number, compound 3's estimate shows no gap at the digits printed; the measured number falls inside the stated range.
By their numbers in this assay, from the lowest: compounds 1, 2 and 3 (each within the scatter of the next).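

In this assay, 4-fluoronaphthalen-1-yl in place of 1-bromonaphthalen-2-yl on this aromatic carbon gives a 1.6-fold higher number from compound 1 to compound 3 (0.20 log units; within the scatter). The position therefore tolerates this exchange of one halogenated naphthyl group for another with no step beyond the scatter, which the earlier pair, differing in more than one place, could not show. No available evidence bears on this result.

The naphthyl attachment point and the halogen change together here, so neither can be read alone. Going by these compounds, the response of this position to a non-naphthyl group, such as an amine or a carboxylic acid, remains open.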